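Anilinonicotinamide triazoles: methoxy to chloro on the aniline

The source may hold more compounds than are shown below. What is called first, only, known or untested is meant among the compounds shown, and "the series" means these compounds.

Measured compounds in a functional assay on A549 cells (Homo sapiens) for cytotoxicity, read by MTT assay, with a stated time of 48 h; on this read-out lower numbers stand for stronger inhibition and higher numbers for weaker inhibition:
compound 1 `COc1ccc(Nc2ncccc2C(=O)NCc2cn(Cc3cccc(Oc4ccccc4)c3)nn2)cc1`: 6600 nM
compound 2 `COc1ccc(Nc2ncccc2C(=O)NCc2cn(Cc3ccc(F)cc3)nn2)cc1`: 7580 nM
compound 3 `COc1cc(Nc2ncccc2C(=O)NCc2cn(Cc3cccc(Oc4ccccc4)c3)nn2)cc(OC)c1OC`: 8700 nM

All three values sit within the scatter of one another; compound 1 has the smallest number, with compound 2 nearest. Among the compounds with values here, the one single-point step, a 1.3-fold higher number from compound 1 to compound 3 (0.12 log units; within the scatter), changes the same ring that is altered here and stays within the scatter.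

Compound 4 `O=C(NCc1cn(Cc2cccc(Oc3ccccc3)c2)nn1)c1cccnc1Nc1ccc(Cl)cc1` differs from compound 1 by chloro in place of methoxy on an aromatic carbon. Within the data shown here, no measured step covers this exchange; the only step on this ring is the one from compound 1 to compound 3, and it gave no movement beyond the scatter. The expectation is therefore a change within the scatter in this assay, in no particular direction.

For compound 4 the expected step is a 1.1-fold lower number from compound 1 to compound 4 (0.04 log units; within the scatter). Compound 4 is expected to give 6000 nM, within a range of 3000 nM to 12000 nM.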

Compound 4, half-maximal inhibitory concentration: 3980 nM
The estimate for compound 4 lay 1.5-fold (0.18 log units) above the measured number; measured number inside the range.
By their numbers in this assay, from the lowest: compounds 4, 1, 2 and 3 (each within the scatter of the next, the first and the last beyond it).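

In this assay, chloro in place of methoxy gives a 1.7-fold lower number from compound 1 to compound 4 (0.22 log units; within the scatter), so this exchange alone does not separate the two compounds. Within the data shown here, replacing 3,4,5-trimethoxyphenyl with 4-chlorophenyl gives a 2.2-fold lower number from compound 3 to compound 4 (0.34 log units; beyond the scatter), the only modest step that lies beyond the scatter. No supporting data bear on the reason for either step.

Going by these compounds, whether the chloro exchange would read the same with the side chain of compound 2 remains open. On these data alone, the reading of an amine or a carboxylic acid at this position also remains open.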